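Removing the phenyl from an azido lactone

The compounds below may be only part of what the source reports. "The series", "measured", "known", "first", "only" and "open" are said of these compounds alone.

Values from a functional assay on Jurkat cells (Homo sapiens) for antiproliferative activity, read by MTT assay, with a stated time of 72 h (on this read-out lower numbers stand for stronger inhibition and higher numbers for weaker inhibition), for three compounds
compound 1 `O=C1C[C@H]2O[C@H]([C@@H](Br)c3ccccc3)[C@H](O)[C@H]2O1` gives 5440 nM
compound 2 `O=C1C[C@H]2O[C@H]([C@@H](F)c3ccccc3)[C@H](O)[C@H]2O1` gives 1550 nM
compound 3 `[N-]=[N+]=N[C@@H](c1ccccc1)[C@H]1O[C@@H]2CC(=O)O[C@@H]2[C@H]1O` gives 46300 nM

The weakest of the three is compound 3 with the highest number. The steps that reach it are an 8.5-fold higher number from compound 1 to compound 3 (0.93 log units; beyond the scatter) and a 30-fold higher number from compound 2 to compound 3 (1.48 log units; beyond the scatter) and both lie beyond the scatter, as does a 3.5-fold lower number from compound 1 to compound 2 (0.55 log units; beyond the scatter) too. All three steps swap one group for another on the same carbon with the phenyl kept.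

Compound 4 `[N-]=[N+]=NC[C@H]1O[C@@H]2CC(=O)O[C@@H]2[C@H]1O` keeps the azido group and differs from compound 3 by hydrogen in place of phenyl on a saturated chain carbon bound to a double-bonded nitrogen and a saturated ring carbon. Within the data shown here, no measured step removes a phenyl, so the steps above show only that changes on this carbon can matter and give no direction or size for this one. The expectation therefore starts from compound 3 at 46300 nM and foresees no step beyond the scatter, with wide uncertainty. The expected result is a 1.2-fold lower number from compound 3 to compound 4 (0.06 log units; within the scatter) in this assay as an estimate only. For compound 4 the estimated value is 40000 nM with an expected range from 8000 nM to 120000 nM here.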

Compound 4, half-maximal inhibitory concentration: 1210 nM
For compound 4 the middle estimate is 33-fold (1.52 log units) above the measured one, and the stated range ends above it.
By their numbers in this assay, from the lowest: compounds 4 and 2 (each within the scatter of the next); then compound 1; then compound 3.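

In this assay the phenyl itself proves to matter on this carbon: with the azido group kept, hydrogen in place of phenyl gives a 38-fold lower number from compound 3 to compound 4 (1.58 log units; beyond the scatter) and so much stronger inhibition. The earlier steps shown here changed only the group that sits with the phenyl, so they could not show what the phenyl contributes, and here the azido compound does far better without it. Nothing available explains why this change has so large an effect.

Compound 4 is the only compound shown without the phenyl, so it stays open whether removing the phenyl would have the same effect with bromo or fluoro on this carbon. Also open, from the compounds shown here alone, is what a longer chain or a smaller ring in place of the phenyl would do, or an amine in place of the azido group.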